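The source may report more compounds than this note shows. Statements on the series, on what has been measured and on what is new or still open speak of the compounds shown alone.

The shared core of these compounds carries a substituent on one aromatic carbon, and that substituent is what varies across the set. Compound 1 `Nc1ccc(S(=O)(=O)N2CCN(c3ncc(C(O)(C(F)(F)F)C(F)(F)F)cc3C#CCO)CC2)cn1` bears a 3-hydroxyprop-1-yn-1-yl group there. In an ADME assay (liver) for metabolic stability, with Liver microsome (Homo sapiens) as the target, using microsomes and NADPH, with a stated time of 30 min, tested at 1 uM (on this read-out lower numbers stand for slow clearance and higher numbers for fast clearance), compound 1 gives < 14 mL.min-1.g-1, which is a limit of the assay rather than a measured number. Compound 2 `Nc1ccc(S(=O)(=O)N2CCN(c3ncc(C(O)(C(F)(F)F)C(F)(F)F)cc3-c3cnccc3F)CC2)cn1` bears a 4-fluoropyridin-3-yl group instead, and in this assay compound 2 gives 17 mL.min-1.g-1. Compound 3 `COc1cncc(-c2cc(C(O)(C(F)(F)F)C(F)(F)F)cnc2N2CCN(S(=O)(=O)c3ccc(N)nc3)CC2)c1` bears a 5-methoxypyridin-3-yl group, and in this assay compound 3 gives 44 mL.min-1.g-1. The step of an at least 1.2-fold higher number from compound 1 to compound 2 (0.08 log units; that floor lies within the scatter) is small, whereas an at least 3.1-fold higher number from compound 1 to compound 3 (0.49 log units; beyond the scatter) and a 2.6-fold higher number from compound 2 to compound 3 (0.41 log units; beyond the scatter) stand out more clearly.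

Compound 4 `Nc1ccc(S(=O)(=O)N2CCN(c3ncc(C(O)(C(F)(F)F)C(F)(F)F)cc3-c3ccc4scnc4c3)CC2)cn1` has not yet been measured. It differs from compound 1 in a single place: 1,3-benzothiazol-5-yl in place of 3-hydroxyprop-1-yn-1-yl on an aromatic carbon. Both measured replacements of the 3-hydroxyprop-1-yn-1-yl group by an aromatic ring gave a higher number, one within the scatter and one beyond it. A rise is therefore expected for compound 4 as well, estimated at an at least 2.8-fold higher number from compound 1 to compound 4 (0.45 log units; beyond the scatter). In this assay compound 4 is expected to give about 40 mL.min-1.g-1, most likely falling between 15 mL.min-1.g-1 and 110 mL.min-1.g-1.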

Compound 4, intrinsic clearance in microsomes: 39 mL.min-1.g-1
Estimate against measurement, compound 4: 1.0-fold (0.01 log units) above; the measured number falls inside the stated range.
By their numbers in this assay, from the lowest: compound 2; then compounds 4 and 3 (each within the scatter of the next). At a limit, below all of these: compound 1.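

In this assay, replacing the 3-hydroxyprop-1-yn-1-yl chain with the two-ring 1,3-benzothiazol-5-yl group gives an at least 2.7-fold higher number from compound 1 to compound 4 (0.44 log units; beyond the scatter), so all three aromatic groups shown give a higher number than the chain, although for the 4-fluoropyridin-3-yl group of compound 2 that rise is not beyond the scatter. Set against the 5-methoxypyridin-3-yl group, the new group gives a 1.1-fold lower number from compound 3 to compound 4 (0.05 log units; within the scatter), and set against the 4-fluoropyridin-3-yl group it gives a 2.3-fold higher number from compound 2 to compound 4 (0.36 log units; beyond the scatter), so adding a second fused ring does not separate compound 4 from compound 3, while compound 2 stays apart from both. The size of the rise from the chain can be read only as a floor, because the number for compound 1 is a limit of the assay and not a measured value: the limit of < 14 mL.min-1.g-1 in this assay, at which 1 of the 4 values shown sits.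

The compounds shown leave open how a plain phenyl ring, a morpholine or a longer chain ending in an amine would read at this position. They also leave open whether another small non-aromatic chain, such as one ending in a carboxylic acid, would share the low reading of compound 1.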